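Swapping Phenyl for Tert-Butyl at the Ring Carbon

A few compounds are considered here, and "the series" means these few. Any claim that something is new, unique, unknown or untested is made for them only; others in the source may bear on it.

Compound 3 `C#CC(=O)N1C(c2ccccc2)SC[C@@H]1C(=O)OCC` stands lowest of the three measured compounds in a functional assay on MV cells (Homo sapiens) for inhibition, read by sulforhodamine B assay (on this read-out lower numbers stand for stronger inhibition and higher numbers for weaker inhibition), where compound 3 gives 400 nM. Its two neighbours sit clearly behind it: compound 1 `C#CC(=O)N1C(c2cccc(F)c2)SC[C@@H]1C(=O)OCC` gives 1700 nM in this assay, and compound 2 `C#CC(=O)N1C(C(CC)CCCC)SC[C@@H]1C(=O)OCC` gives 1600 nM. The step of a 4.3-fold lower number from compound 1 to compound 3 (0.63 log units; beyond the scatter) and the step of a 4.0-fold lower number from compound 2 to compound 3 (0.60 log units; beyond the scatter) are both of modest size yet beyond the scatter, while the step of a 1.1-fold lower number from compound 1 to compound 2 (0.03 log units; within the scatter) lies within it.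

Compound 4 `C#CC(=O)N1C(C(C)(C)C)SC[C@@H]1C(=O)OCC` differs from compound 3 in one place: tert-butyl in place of phenyl on a saturated ring carbon. The measured step that bears most directly on this change is a 4.0-fold lower number from compound 2 to compound 3 (0.60 log units; beyond the scatter), in which 1-ethylpentyl at the same saturated ring carbon was exchanged for phenyl and the number fell. Compound 4 goes the other way, putting tert-butyl where the phenyl stood, so a rise of roughly that size is expected, namely a 3.5-fold higher number from compound 3 to compound 4 (0.54 log units; beyond the scatter). Within the data shown here, no measured step goes from phenyl to tert-butyl itself, so the size remains uncertain. Compound 4 is therefore estimated to give 1400 nM in this assay, with a range from 500 nM to 4000 nM.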

Compound 4, half-maximal inhibitory concentration: 900 nM
Compound 4: the middle estimate sits 1.6-fold (0.19 log units) above what was measured, within the range that was stated.
By their numbers in this assay, from the lowest: compound 3; then compounds 4, 2 and 1 (each within the scatter of the next).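

In this assay, the step of a 2.3-fold higher number from compound 3 to compound 4 (0.35 log units; beyond the scatter) lies beyond the scatter, so phenyl at this saturated ring carbon now stands ahead of a second group without a ring, tert-butyl, as well as 1-ethylpentyl, though compound 1, with its 3-fluorophenyl, goes against any reading that a phenyl-type ring alone is enough. The two other new steps separate nothing: a 1.8-fold lower number from compound 2 to compound 4 (0.25 log units; within the scatter) and a 1.9-fold lower number from compound 1 to compound 4 (0.28 log units; within the scatter) both lie within the scatter, so exchanging 1-ethylpentyl for the smaller tert-butyl, or 3-fluorophenyl for tert-butyl, gives no distinction in this read-out, and among the four compounds only the unsubstituted phenyl of compound 3 stands apart. Nothing at hand offers an independent measurement that would explain these steps.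

The compounds shown leave open whether a saturated ring such as cyclohexyl at this carbon would stand with phenyl or with tert-butyl. They also leave open whether the loss seen with fluoro on the phenyl of compound 1 extends to other substituents on that ring, such as methoxy, chloro or an amine.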